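The compounds below may be only part of what the source reports. "The series", "measured", "known", "first", "only" and "open" are said of these compounds alone.

Compound 1, `CO/N=C(/CCN1CCN(c2ccccn2)CC1)c1ccccc1Cl`, gives 73% in a functional assay on HEK293 cells with D(4) dopamine receptor (Homo sapiens) as the target, read by FLIPR; on this read-out higher numbers stand for larger maximal responses and lower numbers for smaller maximal responses.
Compound 2, `CO/N=C(/CCN1CCN(c2ccccn2)CC1)c1ccccc1C`, gives 72% in this assay.
Compound 3, `CO/N=C(\CCN1CCN(c2ccccn2)CC1)c1cc(C)cc(C)c1`, gives 71% in this assay.

Compound 3 holds the smallest of the three numbers, but the distances are slight: compound 2 is the nearest to it and compound 1 the furthest, and both gaps lie within the scatter, so the three measured compounds cannot be told apart on this read-out. For the measured compounds named here, the only single-point step among them, a number 1 percentage points lower from compound 1 to compound 2 (within the scatter), is also within the scatter.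

Compound 4, `CO/N=C(/CCN1CCN(c2ccccn2)CC1)c1cc(C)cc(C)c1`, is the next compound to be measured. Against compound 3 the difference is the two compounds have the same atoms and bonds and differ only in configuration as drawn: 1 of 1 stereo elements differ; a double bond is drawn E in compound 3 and Z in compound 4. Going by the values given here, none of the measured steps involves a change of configuration at the double bond, so no measured step bears directly on this change; the step from compound 1 to compound 2 concerns a different kind of alteration. With nothing in the data pointing to a shift in either direction, the step is expected to stay within the scatter, though with more uncertainty than for the measured pairs: the expected step is no change at the digits printed from compound 3 to compound 4 (within the scatter). Compound 4 is therefore estimated to give 71% in this assay, within a range of 55% to 85%.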

Compound 4, largest response reached (reported as efficacy), in percent of the reference or control that the assay uses: 83%
Compound 4: the middle estimate sits 12 percentage points below what was measured; measured number inside the range.
By their numbers in this assay, from the lowest: compounds 3, 2, 1 and 4 (each within the scatter of the next, the first and the last beyond it).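

In this assay, for the compounds shown here, the configuration at the double bond is the first change here to carry a step beyond the scatter: a number 12 percentage points higher from compound 3 to compound 4 (beyond the scatter). This step can be assigned to the double bond alone, because the pair offers nothing else that differs: the fact that compounds 3 and 4 differ only in the configuration as drawn. Exchanging the aromatic ring gives a less clear picture, with 3,5-dimethylphenyl in place of 2-methylphenyl giving a number 11 percentage points higher from compound 2 to compound 4 (beyond the scatter) and 3,5-dimethylphenyl in place of 2-chlorophenyl giving a number 10 percentage points higher from compound 1 to compound 4 (within the scatter).

The compounds shown leave open whether the same change of configuration would move the number in the same direction with a 2-methylphenyl, a 2-chlorophenyl or a 4-methoxyphenyl group on that carbon. Also open, from the compounds shown here alone, is what an ethyl group in place of the methyl on oxygen would do to the maximal response.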